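Dichlorophenyl for methoxyphenyl on a weak antiproliferative core

A few compounds are considered here, and "the series" means these few. Any claim that something is new, unique, unknown or untested is made for them only; others in the source may bear on it.

Measured compounds:
compound 1 `COc1ccc(-c2nc(SCC(=O)c3sc(-c4ccccc4)nc3C)[nH]c(=O)c2C#N)cc1` — 48400 nM
compound 2 `COc1ccc(-c2nc(SCC(=O)c3sc(-c4ccc(Cl)cc4)nc3C)[nH]c(=O)c2C#N)cc1` — 35500 nM

In a functional assay on U-87MG ATCC cells for antiproliferative activity against U-87 MG (Homo sapiens), read by MTT assay, with a stated time of 48 h (a higher number here means a weaker inhibitor, a lower number a stronger inhibitor), compound 1 gives 48400 nM. That is the highest of the two numbers recorded, and its nearest neighbour is compound 2, which in this assay gives 35500 nM. Among the compounds with values here, the only measured step, a 1.4-fold lower number from compound 1 to compound 2 (0.13 log units; within the scatter), comes from a chloro in place of hydrogen on an aromatic carbon, and it stays within the scatter, so the two compounds cannot be ranked against each other.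

Compound 3 `Cc1nc(-c2ccccc2)sc1C(=O)CSc1nc(-c2ccc(Cl)c(Cl)c2)c(C#N)c(=O)[nH]1` has not been measured. It differs from compound 1 by 3,4-dichlorophenyl in place of 4-methoxyphenyl on an aromatic carbon. Within the data shown here, no measured step touches this part of the shared core; the one known step, a 1.4-fold lower number from compound 1 to compound 2 (0.13 log units; within the scatter), concerns a different ring and was itself within the scatter. With nothing pointing in either direction, the step from compound 1 to compound 3 in this assay is expected to be small, a 1.3-fold lower number from compound 1 to compound 3 (0.11 log units; within the scatter), and to stay within the scatter. Compound 3 is therefore estimated to give about 38000 nM in this assay, with a likely range from 13000 nM to 110000 nM.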

Compound 3, half-maximal inhibitory concentration: 65000 nM
Compound 3: the middle estimate sits 1.7-fold (0.23 log units) below what was measured, and the stated range covers the measured number.
By their numbers in this assay, from the lowest: compounds 2, 1 and 3 (each within the scatter of the next).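

In this assay, within the data shown here, putting 3,4-dichlorophenyl in place of 4-methoxyphenyl on the aromatic carbon ortho to a cyano group gives a 1.3-fold higher number from compound 1 to compound 3 (0.13 log units; within the scatter) and so provides the first reading at this position, since the earlier pair differed only on another ring. The exchange is not a small one by count: at the same number of heavy atoms, the oxygen and its hydrogen-bond acceptor leave and two chlorines enter, yet the read-out stays within the scatter of compound 1. No measured property of these groups is available to account for this result.

The compounds shown do not establish whether any replacement at this carbon can move the number beyond the scatter, as the only aryl groups seen here are 4-methoxyphenyl and 3,4-dichlorophenyl. Going by these compounds, it also remains open how a group of a different kind at this position, such as a primary amine, a carboxylic acid or a longer alkyl chain, would read in this assay, and whether the chloro on the other ring would add anything when combined with this change.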